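Swapping ethyl for pyridin-3-yl on the shared core

The compounds below may be only part of what the source reports. "The series", "measured", "known", "first", "only" and "open" are said of these compounds alone.

In an ADME assay on microsomes from liver (Mus musculus) for metabolic stability, with a stated time of 10 min, tested at 0.5 uM (a lower number here means that less of the compound is left, a higher number that more of the compound is left), compound 1 (`CCc1noc(C)c1[C@@H]1C[C@@](C)(c2ccc(F)cc2F)N=C(N)S1`) gives 41%, the lowest of the three measured numbers. Compound 2 (`CCc1noc(CC)c1[C@@H]1C[C@@](C)(c2ccc(F)cc2F)N=C(N)S1`) gives 59%, and compound 3 (`Cc1noc(-c2ccc(F)cc2)c1[C@@H]1C[C@@](C)(c2ccc(F)cc2F)N=C(N)S1`) gives 53%.

Compound 4 (`Cc1onc(-c2cccnc2)c1[C@@H]1C[C@@](C)(c2ccc(F)cc2F)N=C(N)S1`) has not yet been measured. It carries pyridin-3-yl in place of ethyl on an aromatic carbon.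

For the measured compounds named here, only one measured step is available, a number 18 percentage points higher from compound 1 to compound 2 (beyond the scatter). It is modest, and it places a methyl on a saturated chain carbon, so it bears only loosely on this swap. Going by the values given here, no measured compound carries pyridin-3-yl. The closest guide is compound 3, which also has a six-membered aromatic ring on its five-membered aromatic ring, though at a different ring atom, and which gives 53%.

A small upward move in this assay is therefore expected, with the estimated step being a number 9 percentage points higher from compound 1 to compound 4 (within the scatter). Compound 4 is estimated at 50%, with an expected range from 32% to 68%.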

Compound 4, percent of the compound remaining: 6%
Estimate against measurement, compound 4: 44 percentage points above, and the stated range ends above it.
By their numbers in this assay, from the lowest: compound 4; then compound 1; then compounds 3 and 2 (each within the scatter of the next).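

Putting pyridin-3-yl in place of ethyl on the aromatic carbon next to the ring nitrogen gives, in this assay, a number 35 percentage points lower from compound 1 to compound 4 (beyond the scatter) as a large step, and it runs opposite to the modest a number 18 percentage points higher from compound 1 to compound 2 (beyond the scatter) seen at the ring atom that bears a methyl group. The place next to the ring nitrogen is thus sensitive to what it carries, which compounds 1 and 2 could not show with ethyl at that place in both, and compound 4 at 6% stands lowest of the four. Nothing measured here accounts for this fall.

The compounds shown leave open whether the fall belongs to the ring nitrogen of pyridin-3-yl or to the six-membered aromatic ring as such. A plain phenyl or a propyl chain at this place would separate those readings.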